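The source may hold more compounds than are shown below. What is called first, only, known or untested is meant among the compounds shown, and "the series" means these compounds.

Compound 1 `Cn1cc(S(=O)(=O)N2CCC(CNC(=O)c3ccc(Cl)cc3Cl)(CC3CC3)CC2)nn1` was tested in an assay on JAR cells for inhibition of sodium- and chloride-dependent glycine transporter 1 (Homo sapiens), read by scintillation counting, with a stated time of 3 h (on this read-out lower numbers stand for stronger inhibition and higher numbers for weaker inhibition), and gave 32 nM. Compound 2 `Cn1ncc(S(=O)(=O)N2CC(CNC(=O)c3ccc(Cl)cc3Cl)(CC3CC3)C2)n1` gave 132 nM in this assay. Of these two numbers, compound 1 has the lower one, and its gap to compound 2 lies beyond the ordinary scatter of repeated measurements, so compound 1 stands as the stronger of the pair. Compound 3 `CCn1cc(S(=O)(=O)N2CCC(CNC(=O)c3ccc(Cl)cc3Cl)(CC3CC3)CC2)nn1` has not yet been measured. It differs from compound 1 by a single change: methyl in place of hydrogen on a saturated chain carbon bound to an aromatic nitrogen. Within the data shown here, no pair of measured compounds here shows the effect of such a change, so its direction is open. The change is small, and the expected step is a 1.3-fold higher number from compound 1 to compound 3 (0.10 log units; within the scatter), within the scatter. Compound 3 is therefore expected to give 40 nM in this assay, with a likely range from 15 nM to 110 nM.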

Compound 3, half-maximal inhibitory concentration: 28.2 nM
Estimate against measurement, compound 3: 1.4-fold (0.15 log units) above; low and high end bracket the measured number.
By their numbers in this assay, from the lowest: compounds 3 and 1 (each within the scatter of the next); then compound 2.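

In this assay, replacing the 1-methyl-1H-1,2,3-triazol-4-yl group of compound 1 with the 1-ethyl-1H-1,2,3-triazol-4-yl group of compound 3 gives a 1.1-fold lower number from compound 1 to compound 3 (0.05 log units; within the scatter), so the two compounds cannot be told apart on this read-out. This is the first step shown at this position, and it indicates that a methyl in place of hydrogen on a saturated chain carbon bound to an aromatic nitrogen is tolerated here. Nothing measured here offers an explanation for this result.

From the compounds shown here alone, it remains open whether this position would also accept a longer chain such as propyl, or an ethyl chain ending in an amine or a carboxylic acid. A single step also cannot show whether the same change would behave alike on the core of compound 2.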